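The source may hold more compounds than are shown below. What is called first, only, known or untested is meant among the compounds shown, and "the series" means these compounds.

Measured so far in a functional assay on HGC-27 cells (Homo sapiens) for cytotoxicity, read by MTT assay, with a stated time of 72 h; on this read-out lower numbers stand for stronger inhibition and higher numbers for weaker inhibition:
Compound 1 `O=[N+]([O-])c1cccc(Nc2nc(SCc3ccc(C(F)(F)F)cc3)nc3ccccc23)c1` gives > 50000 nM, which is a limit of the assay and not a number.
Compound 2 `FC(F)(F)c1ccc(CSc2nc(Nc3ccc(C(F)(F)F)cc3)c3ccccc3n2)cc1` gives 7560 nM.

Among the compounds with values here, compound 2 thus holds the only number in this assay; the value of compound 1 is a limit, namely (the limit of > 50000 nM in this assay, at which 1 of the 2 values shown sits). Within the data shown here, the step between them, an at least 6.6-fold lower number from compound 1 to compound 2 (0.82 log units; beyond the scatter), is the only measured step. Compound 3 `COc1ccc(Nc2nc(SCc3ccc(C(F)(F)F)cc3)nc3ccccc23)cc1OC` differs from compound 2 in one place: 3,4-dimethoxyphenyl in place of 4-(trifluoromethyl)phenyl on a nitrogen on an aromatic ring. Among the measured compounds shown here, the one measured step concerns the same position but a different pair of groups, so it shows only that the group on this nitrogen can move the read-out beyond the scatter, and says nothing about where 3,4-dimethoxyphenyl will fall. For the measured compounds named here, no measured pair compares 3,4-dimethoxyphenyl with 4-(trifluoromethyl)phenyl. The expectation is therefore wide: compound 3 is estimated at 15000 nM, between 4000 nM and 50000 nM. The expected step, a 2.0-fold higher number from compound 2 to compound 3 (0.30 log units; within the scatter), is taken as not clearly beyond the scatter of this assay, with a fair chance that only a limit is reported for compound 3.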

Compound 3, half-maximal inhibitory concentration: 17900 nM
Compound 3: the middle estimate sits 1.2-fold (0.08 log units) below what was measured; measured number inside the range.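

In this assay, within the data shown here, the change from 4-(trifluoromethyl)phenyl to 3,4-dimethoxyphenyl on this nitrogen gives a 2.4-fold higher number from compound 2 to compound 3 (0.37 log units; beyond the scatter), the first step with a number at both ends. Replacing 3-nitrophenyl with 3,4-dimethoxyphenyl gives an at least 2.7-fold lower number from compound 1 to compound 3 (0.44 log units; beyond the scatter), so the three groups now fall in one order, with 4-(trifluoromethyl)phenyl holding the lowest number, 3,4-dimethoxyphenyl the middle one and 3-nitrophenyl the limit, each step beyond the scatter. Going by these compounds, the full size of the step from 3-nitrophenyl stays unknown because compound 1 gives a limit and not a number: the limit of > 50000 nM in this assay, at which 1 of the 3 values shown sits.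

On these data alone, all three groups on this nitrogen are substituted phenyl rings, so it remains open how an unsubstituted phenyl, a benzyl or a saturated ring amine such as morpholine would read here. The rest of the core is the same in all three compounds, which leaves open whether the order of these groups would hold if, for example, a carboxylic acid replaced the trifluoromethyl on the other benzyl group.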